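This account rests on a few compounds, and the source may have more. Where it says the series, first, only, none or still open, it means among the compounds named here.

Measured so far:
compound 1, `CC(C)Cc1nn(-c2nccs2)cc1C(=O)NCc1ccc(F)cc1F` — 83600 nM
compound 2, `CCOC(=O)c1cn(-c2ccccc2F)nc1CC(C)C` — > 100000 nM

For the measured compounds named here, in a toxicity assay on HepG2 2.2.15 cells (Homo sapiens) for cytotoxicity, read by CCK-8 assay, with a stated time of 8 days (on this read-out higher numbers stand for lower toxicity in this test and lower numbers for higher toxicity in this test), compound 1 gives 83600 nM, the only actual number among the two values recorded. Compound 2 gives > 100000 nM, which is a limit of the assay rather than a number. Compound 1 therefore stands as the single measured point, while the remaining value sits at the limit of > 100000 nM in this assay, at which 1 of the 2 values shown sits. Compound 3, `CC(C)Cc1nn(-c2nccs2)cc1C(=O)NCc1ccccc1F`, differs from compound 1 in one place: hydrogen in place of fluoro on an aromatic carbon. Going by the values given here, no step between two measured compounds is available, so the effect of this change cannot be read from any comparison already made. Since compound 1 gives 83600 nM and only a fluoro group is exchanged for hydrogen, the change from compound 1 to compound 3 in this assay is expected to be small, in no particular direction, and not beyond the usual scatter of repeated measurements. Compound 3 is estimated at 90000 nM, with a range from 40000 nM to 200000 nM. This expectation corresponds to a step of a 1.1-fold higher number from compound 1 to compound 3 (0.03 log units; within the scatter).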

Compound 3, half-maximal cytotoxic concentration: > 100000 nM
Compound 3 was reported as a limit; the forecaster's own chance of this, stated with the estimate: 40%; middle value at least 1.1-fold (0.04 log units) away from the limit.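

Going from 2,4-difluorophenyl to 2-fluorophenyl gives the first comparison of compounds differing in one place in this assay, and the step reads an at least 1.1-fold higher number from compound 1 to compound 3 (0.07 log units; that floor lies within the scatter). Compound 3 gives > 100000 nM, which is a limit of the assay and not a number. Taking this fluoro group off the ring therefore shows no sign of raising toxicity in this test, but the true size of the step stays unknown, and most of the values now sit at the top of what the assay can report: the limit of > 100000 nM in this assay, at which 2 of the 3 values shown sit.

Going by these compounds, whether a different group at this place, such as chloro, methoxy or an amine, would shift the number remains open. On these data alone, what hydrogen in place of the remaining fluoro group would do is also open.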